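A few compounds are considered here, and "the series" means these few. Any claim that something is new, unique, unknown or untested is made for them only; others in the source may bear on it.

Of the compounds shown here, three with a shared core have been measured so far in an ADME assay on H9 cells (Homo sapiens) for cytotoxicity, read by XTT assay, with a stated time of 6 days; a lower number here means that less compound is tolerated, a higher number that more compound is tolerated. Compound 1 (`Cc1cc(Br)cc(C)c1Oc1cc(Nc2ccc(C#N)cc2)c(N)cc1N`) gives 38400 nM there. Compound 2 (`Cc1cccc(C)c1Oc1ccc([N+](=O)[O-])c(Nc2ccc(C#N)cc2)c1`) gives 69600 nM there. Compound 3 (`Cc1cc(C)c(Oc2cc(Nc3ccc(C#N)cc3)c(N)cc2[N+](=O)[O-])c(C)c1`) gives 32200 nM there too. The distance from compound 2 to compound 1 stays within the scatter, so these two cannot be ranked, whereas compound 3 lies lower than compound 2 by a gap just beyond the scatter.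

Compound 4 (`Cc1cc(C=O)cc(C)c1Oc1ccc([N+](=O)[O-])c(Nc2ccc(C#N)cc2)c1`) has not yet been measured. It differs from compound 2 in one place, formyl in place of hydrogen on an aromatic carbon, and that carbon is meta to two methyl groups and para to a large group. Among the measured compounds shown here, no measured pair isolates a single change, so this step has no direct precedent in this assay and any expectation is loose. The measured numbers lie close together, with compound 3 at 32200 nM and compound 2 at 69600 nM as the two ends, which suggests a modest move. The expected step (a 1.7-fold lower number from compound 2 to compound 4 (0.24 log units; within the scatter)) is toward a lower number and about the size of the scatter. Compound 4 is estimated at 40000 nM with an expected range of 15000 nM to 85000 nM in this assay once it is tested.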

Compound 4, half-maximal cytotoxic concentration: 14200 nM
The estimate for compound 4 lay 2.8-fold (0.45 log units) above the measured number, and the stated range ends above it.
By their numbers in this assay, from the lowest: compound 4; then compounds 3, 1 and 2 (each within the scatter of the next, the first and the last beyond it).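

In this assay, formyl in place of hydrogen on an aromatic carbon, meta to two methyl groups and para to a large group, gives a 4.9-fold lower number from compound 2 to compound 4 (0.69 log units; beyond the scatter). This is the first change in the series confined to one place, and its step lies beyond the scatter, so this carbon is shown not to be indifferent to substitution in this assay: adding formyl there goes with less compound being tolerated. The data shown offer no measurement that accounts for this step, so the reason for it remains unknown.

With only one step at this carbon, the compounds shown cannot separate what is particular to formyl from what any added group might do there, and whether a hydroxymethyl or a carboxylic acid on that carbon would move the number in the same direction or as far stays open. Going by these compounds, it is equally open whether formyl would give a step of similar size on the core of compound 1 or of compound 3, which differ from compound 2 in more than one place.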